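The source may hold more compounds than are shown below. What is called first, only, known or untested is meant among the compounds shown, and "the series" means these compounds.

Three compounds have so far been measured in an in vitro ADME assay on microsomes from liver (Homo sapiens) for pharmacokinetics, read by LC-MS, with a stated time of 10 min, tested at 1 uM; a higher number here means faster removal of the compound, a lower number slower removal:

compound 1 `CN1C[C@H](C(=O)Nc2ccc(Br)cc2)[C@@H](c2ccc(/C=C/C(=O)Nc3ccccc3N)cc2)C1`, 3 mL/min/kg
compound 2 `Cc1cccc(NC(=O)[C@H]2CN(C)C[C@@H]2c2ccc(/C=C/C(=O)Nc3ccccc3N)cc2)c1`, 14 mL/min/kg
compound 3 `CN1C[C@H](C(=O)Nc2ccc(Cl)cc2F)[C@@H](c2ccc(/C=C/C(=O)Nc3ccccc3N)cc2)C1`, 11 mL/min/kg

Compound 1 gives the lowest of the three numbers. In both measured steps, exchanging the aryl group on the amide-type nitrogen pushed the number upward: a 4.7-fold higher number from compound 1 to compound 2 (0.67 log units; beyond the scatter) and a 3.7-fold higher number from compound 1 to compound 3 (0.56 log units; beyond the scatter). Compound 2 and compound 3 lie within the scatter of each other, as a 1.3-fold lower number from compound 2 to compound 3 (0.10 log units; within the scatter) shows.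

Compound 4 `CN1C[C@H](C(=O)N2CCCCC2)[C@@H](c2ccc(/C=C/C(=O)Nc3ccccc3N)cc2)C1` has not yet been measured in this assay. It differs from compound 1 in one place: piperidin-1-yl in place of (4-bromophenyl)amino on a carbonyl carbon. Neither measured step bears on this change directly, since both kept an aryl group on the amide-type nitrogen and only altered its substituents, whereas here the whole (4-bromophenyl)amino group leaves and piperidin-1-yl enters on the carbonyl carbon. What the two steps do show is that compound 1 holds the lowest number and that each change at this part of the molecule moved the number upward. The author therefore expects compound 4 to move in the same direction, by a step of about a 2.7-fold higher number from compound 1 to compound 4 (0.43 log units; beyond the scatter), while allowing that it could remain within the scatter of compound 1. The estimate for compound 4 in this assay is 8 mL/min/kg, with a range from 3 mL/min/kg to 25 mL/min/kg.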

Compound 4, clearance: 9 mL/min/kg
Compound 4: the middle estimate sits 1.1-fold (0.05 log units) below what was measured; the range from low to high includes it.
By their numbers in this assay, from the lowest: compound 1; then compounds 4, 3 and 2 (each within the scatter of the next).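

Taking the whole (4-bromophenyl)amino group off the carbonyl carbon and putting piperidin-1-yl there gives, in this assay, a 3.0-fold higher number from compound 1 to compound 4 (0.48 log units; beyond the scatter), so the position accepts a non-aromatic ring with no amide hydrogen and the number still rises by a step of the same order as the earlier exchanges of one aryl group for another. The new compound also cannot be separated from the two other aryl amides, with a 1.2-fold lower number from compound 3 to compound 4 (0.09 log units; within the scatter) and a 1.6-fold lower number from compound 2 to compound 4 (0.19 log units; within the scatter), which shows that having an aromatic ring and an amide hydrogen at this place does not by itself give a low number: among these four compounds, only compound 1 stands apart. Nothing available explains why compound 1 stands apart.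

The compounds shown leave open whether the low number of compound 1 goes with its bromine atom, which 4-chlorophenyl or unsubstituted phenyl on the amide nitrogen could test. They also leave open whether morpholin-4-yl or an open-chain dimethylamino group on the carbonyl carbon would give a number close to that of compound 4.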